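The source may hold more compounds than are shown below. What is called first, only, known or untested is meant among the compounds shown, and "the series" means these compounds.

Measured so far in an assay for inhibition of solute carrier family 22 member 12 (Homo sapiens), read by scintillation counting, with a stated time of 60 min, tested at 50 uM; on this read-out lower numbers stand for less inhibition and higher numbers for more inhibition at the one concentration tested (going by the name of the read-out):
compound 1, `CCc1cc2cc(OC)cc(C(=O)c3ccc(OC)cc3)c2o1`, gives 5.2%
compound 2, `CCc1oc2ccc(O)cc2c1C(=O)c1ccc(OC)cc1`, gives 12.9%
compound 3, `CCc1oc2ccc(O)cc2c1C(=O)c1ccc(O)cc1`, gives 96.5%

Compound 1 has the lowest of the three numbers; its nearest neighbour is compound 2, and the two lie within the usual scatter of each other, so no order between them is claimed. Compound 3 stands far above both.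

Among the compounds with values here, the one stepwise change that is measured runs from compound 2 to compound 3: hydrogen in place of methyl on an oxygen on an aromatic ring. In this assay this gave a number 83.6 percentage points higher from compound 2 to compound 3 (beyond the scatter), a large step well beyond the scatter.

Compound 4, `CCc1cc2cc(OC)cc(C(=O)c3ccc(O)cc3)c2o1`, is not yet measured. It differs from compound 1 by hydrogen in place of methyl on an oxygen on an aromatic ring, the same change, at the same kind of place, as that from compound 2 to compound 3. The two cores, that of compound 1 and that of compound 2, differ in more than one place, and the difference between them is not broken down here.

Within the data shown here, the expectation for compound 4 rests on the single measured step: because a number 83.6 percentage points higher from compound 2 to compound 3 (beyond the scatter) was large, a step of comparable direction is expected from compound 1 to compound 4, though the different core leaves the size uncertain; the step expected is a number 54.8 percentage points higher from compound 1 to compound 4 (beyond the scatter). Compound 4 is estimated at 60% in this assay, within a range of 20% to 95%.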

Compound 4, a percentage reported as inhibition, at one concentration (the size of the read-out at that concentration, not a potency): 60%
Beside the measured number, compound 4's estimate shows no gap at the digits printed; the measured number falls inside the stated range.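

In this assay, methoxy to hydroxy on the aromatic ring gave a number 54.8 percentage points higher from compound 1 to compound 4 (beyond the scatter), so on the two cores shown this change goes the same way, upward, and the step is large on both. The size of the step does not carry over unchanged from one core to the other: the same change on two cores in this assay, a number 83.6 percentage points higher (beyond the scatter) from compound 2 to compound 3 and a number 54.8 percentage points higher (beyond the scatter) from compound 1 to compound 4, 28.8 percentage points apart, beyond the scatter of two such steps Two cores are a narrow base for any rule, and they differ in more than one place, so these numbers show that the size of the step depends on the core, but they do not show which part of the core is responsible for the gap.

Still open is how the read-out responds when the hydroxy is replaced by another group at the same place, such as an amine or a carboxylic acid, since only methoxy and hydroxy appear there in the compounds shown. Also open, on these data alone, is whether hydroxy in place of the methoxy that remains on the core of compound 4 changes the number, and what a longer chain in place of the ethyl group does on either core.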